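The source may hold more compounds than are shown below. What is called first, only, known or untested is meant among the compounds shown, and "the series" means these compounds.

Compound 1 `COCCNC(=O)CNc1ncc2c(Br)nn(-c3ccc4ncccc4c3)c2n1` is the starting point of this account. Among the compounds with values here, in an assay on SK-OV-3 cells for inhibition of eIF-2-alpha kinase GCN2 (Homo sapiens) (on this read-out lower numbers stand for stronger inhibition and higher numbers for weaker inhibition), compound 1 gives "nd" (no result reported), so there is no number on which it can be placed, and no step from it can be measured. The nearest measured relative is compound 2 `COCCNC(=O)[C@H]1CC[C@@H](Nc2ncc3c(Br)nn(-c4ccc5ncccc5c4)c3n2)C1`, whose side chain already carries the five-membered non-aromatic ring of carbon only; in this assay compound 2 gives 156 nM.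

Compound 3 `CNC(=O)[C@]1(C)CC[C@@H](Nc2ncc3c(Br)nn(-c4ccc5ncccc5c4)c3n2)C1` arises from compound 1 by the change (a group of 10 heavy atoms (8 carbon, 1 nitrogen, 1 oxygen; one five-membered non-aromatic ring of carbon only) in place of a group of 8 heavy atoms (5 carbon, 1 nitrogen, 2 oxygen; no ring), on a nitrogen on an aromatic ring). With compound 1 unmeasured, the size and direction of the step from compound 1 to compound 3 in this assay cannot be stated, and no step beyond the scatter can be claimed either way.

What can be said rests on compound 2 alone: its value of 156 nM belongs to a close analogue that shares the ring-bearing side chain with compound 3. On that basis compound 3 is expected to give about 150 nM in this assay, estimated within a range from 50 nM to 500 nM.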

Compound 3, half-maximal inhibitory concentration: 21 nM
Beside the measured number, compound 3's estimate is 7.1-fold (0.85 log units) above it; the measured number lies below the stated range.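

Within the data shown here, compound 1 has no number in this assay and so, although compound 3 gives 21 nM there, no step from compound 1 to compound 3 can be read. No measurement shown here accounts for this result. The compounds shown leave open whether the group entering on the nitrogen strengthens or weakens inhibition relative to the ((2-methoxyethyl)carbamoyl)methyl group it replaces.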